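Ester to ester: a longer acyl chain on a shikonin derivative

The source may hold more compounds than are shown below. What is called first, only, known or untested is meant among the compounds shown, and "the series" means these compounds.

Measured so far in a functional assay on DU-145 cells (Homo sapiens) for cytotoxicity, read by MTT assay; a lower number here means a stronger inhibitor, a higher number a weaker inhibitor:
compound 1, `CC(C)=CC[C@@H](OC(=O)C1CCOC1)C1=CC(=O)c2c(O)ccc(O)c2C1=O`, 47500 nM
compound 2, `COCCO[C@H](CC=C(C)C)C1=CC(=O)c2c(O)ccc(O)c2C1=O`, 43200 nM
compound 3, `CC(C)=CC[C@@H](OCCO)C1=CC(=O)c2c(O)ccc(O)c2C1=O`, 9900 nM

Compound 1 stands at the highest number of the three. Compound 2 sits within the scatter of it, the step being a 1.1-fold lower number from compound 1 to compound 2 (0.04 log units; within the scatter); compound 3 lies beyond it, with a 4.8-fold lower number from compound 1 to compound 3 (0.68 log units; beyond the scatter). Going by the values given here, the only change that moved the number beyond the scatter was a 4.4-fold lower number from compound 2 to compound 3 (0.64 log units; beyond the scatter), the gain of a free hydroxyl.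

Compound 4 is `CCCCC(CC(=O)O[C@H](CC=C(C)C)C1=CC(=O)c2c(O)ccc(O)c2C1=O)OC(C)=O`. It differs from compound 1 in this way: 2-acetoxyhexyl in place of oxolan-3-yl on a carbonyl carbon. The new compound keeps the ester and adds no hydrogen-bond donor; it brings only a further acceptor, the acetoxy group, together with a longer chain. Among the compounds with values here, none of the measured steps tests such an acyl exchange directly. The nearest guide is the step from the ester of compound 1 to the ether of compound 2, which stayed within the scatter, and the lesson of compound 3 that only a donor brought a clear gain. A step of no size beyond the scatter is therefore expected, a 1.2-fold lower number from compound 1 to compound 4 (0.07 log units; within the scatter), and compound 4 is estimated at 40000 nM, with a range from 15000 nM to 100000 nM.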

Compound 4, half-maximal inhibitory concentration: 67700 nM
Estimate against measurement, compound 4: 1.7-fold (0.23 log units) below; measured number inside the range.
By their numbers in this assay, from the lowest: compound 3; then compounds 2, 1 and 4 (each within the scatter of the next).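

Compound 4 is the first of these compounds in which the ester stays and only the group on the carbonyl carbon is exchanged, and in this assay the exchange gives a 1.4-fold higher number from compound 1 to compound 4 (0.15 log units; within the scatter). An open 2-acetoxyhexyl group of 10 heavy atoms, carrying 2 hydrogen-bond acceptors and no ring, thus stands in place of the 5 heavy atoms of the oxolan-3-yl ring without moving the number beyond the scatter, so this position accepts a large change in the acyl group with no measurable consequence in this cell assay, and the clear gain seen so far remains confined to the 2-hydroxyethyl group of compound 3. Nothing available explains why the number holds across so large an exchange.

The compounds shown leave open whether a free hydroxyl in place of the acetoxy group on the hexyl chain would bring to the ester the kind of step that the 2-hydroxyethyl ether showed. They also leave open how a carboxylic acid or an amine at the end of the acyl chain would read, or whether a much shorter acetyl group would stay within the scatter of compound 1.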